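This account rests on a few compounds, and the source may have more. Where it says the series, first, only, none or still open, it means among the compounds named here.

In a functional assay on A549 cells (Homo sapiens) for inhibition, read by MTT assay, with a stated time of 24 h (a higher number here means a weaker inhibitor of growth, a lower number a stronger inhibitor of growth), compound 3 (`Cn1cc(-c2nc3ccccc3n2C(=O)c2ccccc2Br)c2cc(Br)ccc21`) gives 46700 nM and lies within the scatter of compound 1 (`COc1ccc2c(c1)c(-c1nc3ccccc3n1C(=O)c1cccc(Br)c1)cn2C`), which gives 24800 nM as its value. Compound 2 (`COc1ccc(C(=O)n2c(-c3cn(C)c4ccc(Br)cc34)nc3ccccc32)cc1`) gives 11300 nM on the same read-out. Within the data shown here, the only measured step that isolates a single change is a 4.1-fold higher number from compound 2 to compound 3 (0.62 log units; beyond the scatter) and it lies beyond the scatter.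

The next structure is compound 4 (`Cn1cc(-c2nc3ccccc3n2C(=O)c2cccc(Br)c2)c2cc(Br)ccc21`). The change is 3-bromophenyl in place of 2-bromophenyl on a carbonyl carbon and amounts to 3-bromophenyl in place of 2-bromophenyl on a carbonyl carbon, with the rest of the structure untouched.

Among the measured compounds shown here, no measured pair isolates this exchange. The measured step of a 4.1-fold higher number from compound 2 to compound 3 (0.62 log units; beyond the scatter) in this same place replaced a different group, so it serves only as a loose upper guide to size. Compound 1 also carries 3-bromophenyl on a carbonyl carbon and gives 24800 nM in this assay even though its core differs from that of compound 4, which points modestly toward a lower number. The expected change is a 1.7-fold lower number from compound 3 to compound 4 (0.24 log units; within the scatter) and so is not expected to clear the scatter. Compound 4 is estimated at 27000 nM with an expected range from 11000 nM to 60000 nM for this compound.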

Compound 4, concentration for 50% growth inhibition: 38500 nM
The estimate for compound 4 lay 1.4-fold (0.15 log units) below the measured number; the range from low to high includes it.
By their numbers in this assay, from the lowest: compound 2; then compounds 1, 4 and 3 (each within the scatter of the next).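

In this assay, 3-bromophenyl in place of 2-bromophenyl on a carbonyl carbon gives a 1.2-fold lower number from compound 3 to compound 4 (0.08 log units; within the scatter) and thus no readable difference between these two bromophenyl groups on the shared core. The step with 3-bromophenyl in place of 4-methoxyphenyl, a 3.4-fold higher number from compound 2 to compound 4 (0.53 log units; beyond the scatter) and beyond the scatter, now stands with the earlier 4.1-fold higher number from compound 2 to compound 3 (0.62 log units; beyond the scatter) and beyond the scatter, so among compounds 2, 3 and 4 the readable gap lies between 4-methoxyphenyl and either bromophenyl group, and none of the three goes against this. With 3-bromophenyl kept on the carbonyl carbon, bromo in place of methoxy on an aromatic carbon gives a 1.6-fold higher number from compound 1 to compound 4 (0.19 log units; within the scatter) and no readable change at that second place.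

The compounds shown leave open whether the gap follows the methoxy group itself or its location on the ring, a question that 4-bromophenyl on the same carbonyl carbon would separate. They also leave open how an amine or a carboxylic acid on this phenyl ring would read on the same scale. Nothing at hand gives a reason for these numbers.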